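Thiophen-2-yl in place of furan-2-yl: notes on compound 4

The source may report more compounds than this note shows. Statements on the series, on what has been measured and on what is new or still open speak of the compounds shown alone.

- compound 1 `COc1cc(-c2cccc3nc(-c4ccc(Br)cc4)oc23)cc(OC)c1OC` gives > 25000 nM (a limit)
- compound 2 `COc1cc(-c2cccc3nc(-c4ccc(Cl)cc4)oc23)cc(OC)c1OC` gives > 25000 nM (a limit)
- compound 3 `COc1cc(-c2cccc3nc(-c4ccco4)oc23)cc(OC)c1OC` gives > 25000 nM (a limit)

In a functional assay on MCF7 cells (Homo sapiens) for antiproliferative activity, read by MTT assay, with a stated time of 48 h (on this read-out lower numbers stand for stronger inhibition and higher numbers for weaker inhibition), compound 3 gives > 25000 nM as a limit and not as a number. The set as a whole shows the limit of > 25000 nM in this assay, at which 3 of the 3 values shown sit, and offers no number for placing compound 3 against the others.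

Compound 4 `COc1cc(-c2cccc3nc(-c4cccs4)oc23)cc(OC)c1OC` differs from compound 3 in one group, with thiophen-2-yl in place of furan-2-yl on an aromatic carbon of a five-membered aromatic ring with 1 nitrogen and 1 oxygen. The counted change is thiophen-2-yl in place of furan-2-yl on an aromatic carbon and nothing else differs.

Within the data shown here, three measured steps bear on this. The most direct are a step that the two limits leave unreadable from compound 2 to compound 3 and a step that the two limits leave unreadable from compound 1 to compound 3 at this same place, and the third is a step that the two limits leave unreadable from compound 1 to compound 2 within the 4-substituted phenyl group. None of them has a size that can be carried over. In this assay no step beyond the scatter is expected in either direction, and a further limit is the likeliest report.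

The expected step is a step that the limit leaves unreadable from compound 3 to compound 4 as an estimate only. For compound 4 the estimate is 30000 nM with an expected range from 10000 nM to 60000 nM in this series.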

Compound 4, half-maximal inhibitory concentration: > 25000 nM
Compound 4: no number, only a limit; the forecaster's own chance of this, stated with the estimate: 80%; the middle value lies beyond the limit too.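

In this assay compound 4 gives > 25000 nM as a limit and not a number. No new step can be read between compound 4 and compound 1, compound 2 or compound 3, as all four rest on one limit: the limit of > 25000 nM in this assay, at which 4 of the 4 values shown sit.

The compounds shown leave open whether any group at this place gives a readable value in this assay on the shared core.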